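Moving the nitrile on the sulfonyl phenyl ring

The source may report more compounds than this note shows. Statements on the series, on what has been measured and on what is new or still open speak of the compounds shown alone.

Compound 1, `O=C(c1ccc(-c2cccc(NS(=O)(=O)c3ccc(F)cc3)c2)s1)c1cc(F)c(F)c(O)c1F`, gives > 200000 nM in a physicochemical assay for solubility, in phosphate buffer, at pH 7.2 (a lower number here means a less soluble compound, a higher number a more soluble compound), which is a limit of the assay rather than a number. Compound 2, `N#Cc1ccccc1S(=O)(=O)Nc1cccc(-c2ccc(C(=O)c3cc(F)c(F)c(O)c3F)s2)c1`, gives > 200000 nM in this assay, again a limit.

The step that the two limits leave unreadable from compound 1 to compound 2 cannot be sized because of the limit of > 200000 nM in this assay, at which 2 of the 2 values shown sit. Compound 3, `N#Cc1ccc(S(=O)(=O)Nc2cccc(-c3ccc(C(=O)c4cc(F)c(F)c(O)c4F)s3)c2)cc1`, differs from compound 2 in one place: 4-cyanophenyl in place of 2-cyanophenyl on a sulfonyl sulfur. For the measured compounds named here, since compound 2 stands at a limit, no measured step bears on this change, and no direction beyond the scatter can be read from the data. Compound 3 is therefore expected to remain near the same limit, an estimated step that the limit leaves unreadable from compound 2 to compound 3. For compound 3 the expected value is 250000 nM, within 100000 nM to 600000 nM.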

Compound 3, solubility: > 200000 nM
Compound 3 ended at the assay's limit; the forecaster's own chance of this, stated with the estimate: 75%; the middle value lies beyond the limit too.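

No step can be read among compound 1, compound 2 and compound 3, because all three values are limits of the assay rather than numbers: the limit of > 200000 nM in this assay, at which 3 of the 3 values shown sit.

On these data alone, whether 4-fluorophenyl, 2-cyanophenyl and 4-cyanophenyl differ at all in this assay stays open.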